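A few compounds are considered here, and "the series" means these few. Any claim that something is new, unique, unknown or untested is made for them only; others in the source may bear on it.

Series notes. Compound 1 `Cc1cc(C(=O)O)nn1Cc1cc(Br)ccc1OCc1ccc(Cl)cc1Cl` is the reference point; in an assay on CHO-K1 cells for displacement of a labelled ligand from prostaglandin E2 receptor EP1 subtype (Homo sapiens) (on this read-out lower numbers stand for stronger inhibition and higher numbers for weaker inhibition), compound 1 gives 0.132 nM. Among the compounds with values here, its only measured neighbour, compound 2 `Cc1cc(C(=O)O)nn1Cc1cc(Br)ccc1OCc1cccc(Cl)c1`, gives 115 nM in this assay. Within the data shown here, the single step recorded so far, an 870-fold higher number from compound 1 to compound 2 (2.94 log units; beyond the scatter), concerns the chlorinated ring on the ether side and leaves the bromo untouched. Of the two numbers in hand, compound 1 holds the lower one, by a margin beyond the scatter.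

Compound 3 `Cc1cc(C(=O)O)nn1Cc1ccccc1OCc1ccc(Cl)cc1Cl` is the next step out from compound 1: hydrogen in place of bromo on an aromatic carbon. Among the measured compounds shown here, no measured pair bears on this change; the one recorded step, an 870-fold higher number from compound 1 to compound 2 (2.94 log units; beyond the scatter), alters a different part of the molecule and gives no guide to the size or direction of the bromo-to-hydrogen step. The shared core and the 2,4-dichlorophenyl group of compound 1 are both kept, so most of the molecule is unchanged. Working expectation: a moderate rise in the number for compound 3, estimated as a 7.6-fold higher number from compound 1 to compound 3 (0.88 log units; beyond the scatter) in this assay, well short of the recorded step. Compound 3 is therefore estimated at 1 nM, with a range of 0.2 nM to 8 nM.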

Compound 3, half-maximal inhibitory concentration: < 2000 nM
Compound 3 was reported as a limit; the forecaster's own chance of this, stated with the estimate: 2%; the middle value lies beyond the limit too.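

Within the data shown here, for compound 3 the result is a limit, so no step from compound 1 to compound 3 can be read from it: the limit of < 2000 nM in this assay, at which 1 of the 3 values shown sits. The compounds shown leave open how large the change is in this assay when hydrogen replaces bromo with the 2,4-dichlorophenyl group kept, and in which direction it runs.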